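The source may report more compounds than this note shows. Statements on the series, on what has been measured and on what is new or still open speak of the compounds shown alone.

Compound 3 `CC(C)c1cccc(C(C)C)c1NC(=O)NCC1(c2cccc(N(C)C)c2)CCCC1` gives 33 nM in an assay on microsomes for inhibition of acyl-CoA:cholesterol acyltransferase (Oryctolagus cuniculus); on this read-out lower numbers stand for stronger inhibition and higher numbers for weaker inhibition; compound 1 `CC(C)c1cccc(C(C)C)c1NC(=O)NCC1(c2ccc(Cl)cc2)CCCC1` gives 32 nM and compound 2 `CC(C)c1cccc(C(C)C)c1NC(=O)NCC1(c2ccc(C(F)(F)F)cc2)CCCC1` gives 66 nM, so compound 3 holds the second highest of the three numbers, with both neighbours within the scatter of it. Compound 4 `CC(C)c1cccc(C(C)C)c1NC(=O)NCC1(c2ccc(NCCO)cc2)CCCC1` differs from compound 3 by 4-((2-hydroxyethyl)amino)phenyl in place of 3-(dimethylamino)phenyl on a saturated ring carbon. Two measured steps swap the aryl group on the same saturated ring carbon, a 1.0-fold higher number from compound 1 to compound 3 (0.01 log units; within the scatter) and a 2.0-fold lower number from compound 2 to compound 3 (0.30 log units; within the scatter), both within the scatter; the step of a 2.1-fold higher number from compound 1 to compound 2 (0.31 log units; beyond the scatter) alters a substituent on an aromatic carbon and was modest. Among the compounds with values here, no measured step adds the hydroxyethylamino group, so the expected step is a 1.1-fold higher number from compound 3 to compound 4 (0.03 log units; within the scatter), none beyond the scatter. Compound 4 is estimated at 35 nM, between 12 nM and 110 nM.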

Compound 4, half-maximal inhibitory concentration: 25 nM
Estimate against measurement, compound 4: 1.4-fold (0.15 log units) above; low and high end bracket the measured number.
By their numbers in this assay, from the lowest: compounds 4, 1, 3 and 2 (each within the scatter of the next, the first and the last beyond it).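

On the saturated ring carbon, this assay accommodates 4-((2-hydroxyethyl)amino)phenyl, which carries hydrogen-bond donors absent from 3-(dimethylamino)phenyl, with a 1.3-fold lower number from compound 3 to compound 4 (0.12 log units; within the scatter) and a 1.3-fold lower number from compound 1 to compound 4 (0.11 log units; within the scatter). Only the comparison with trifluoromethyl goes beyond the scatter, with a 2.6-fold lower number from compound 2 to compound 4 (0.42 log units; beyond the scatter), so the new group is clearly separated from that substituent alone. No measurement at hand accounts for these steps. The compounds shown do not separate the contribution of the hydroxyl from that of the amine nitrogen. As far as these compounds go, how a longer chain or a carboxylic acid would read here also remains open.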